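The compounds below may be only part of what the source reports. "The series", "measured", "known", "first", "only" and "open" are said of these compounds alone.

- Compound 1 `COc1cc(-c2nnc(SCc3ccc(C)cc3)n2-c2ccc(N(C)C)cc2)cc(OC)c1OC`: 37300 nM
- Compound 2 `CCOC(=O)CSc1nnc(-c2cc(OC)c(OC)c(OC)c2)n1-c1ccc(N(C)C)cc1`: > 60000 nM

In a functional assay on PC-3 cells (Homo sapiens) for inhibition, read by MTT assay, with a stated time of 48 h (a lower number here means a stronger inhibitor, a higher number a weaker inhibitor), the entry for compound 2, > 60000 nM, is a limit and not a number. The next analogue, compound 3 `COc1cc(-c2nnc(SCC(=O)Nc3ccc(Cl)cc3)n2-c2ccc(N(C)C)cc2)cc(OC)c1OC`, carries (4-chlorophenyl)amino in place of ethoxy on a carbonyl carbon. Going by the values given here, only one measured step bears on this change, an at least 1.6-fold higher number from compound 1 to compound 2 (0.20 log units; that floor lies within the scatter), and it is a floor within the scatter, so it offers weak guidance. Compound 3 again holds a six-membered aromatic ring, as does compound 1 at 37300 nM, so a modest move towards a lower number is expected. The expected size of the move is an at least 2.0-fold lower number from compound 2 to compound 3 (0.30 log units; that floor lies within the scatter). For compound 3 the estimated value is 30000 nM, with an expected range of 8000 nM to 60000 nM.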

Compound 3, half-maximal inhibitory concentration: > 60000 nM
Compound 3: only a limit was reported; the forecaster's own chance of this, stated with the estimate: 30%; middle value at least 2.0-fold (0.30 log units) away from the limit.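

A six-membered aromatic ring, entering as (4-chlorophenyl)amino on a carbonyl carbon, does not give compound 3 a readable number in this assay: its entry is again a limit. Going by these compounds alone, the step from compound 2 cannot be read, and the only readable step is an at least 1.6-fold higher number from compound 1 to compound 3 (0.20 log units; that floor lies within the scatter). At this position, the readings now stand mostly at a limit: the limit of > 60000 nM in this assay, at which 2 of the 3 values shown sit.

As far as these compounds go, what stays open is how a carboxylic acid or a longer chain would read here, and whether any group on this carbonyl carbon gives a number rather than a limit.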